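The compounds below may be only part of what the source reports. "The series", "measured", "known", "first", "only" and "open" are said of these compounds alone.

Measured so far:
- compound 1 `Cc1cc(/C=C/C#N)cc(C)c1Oc1cc(NCCN2CCN(C)CC2)nc(Nc2ccc(C#N)cc2)c1`, 7960 nM in an ADME assay on MT4 cells (Homo sapiens) for cytotoxicity, read by MTT assay, with a stated time of 5 days; on this read-out lower numbers stand for higher toxicity in this test and higher numbers for lower toxicity in this test
- compound 2 `Cc1cc(/C=C/C#N)cc(C)c1Oc1cc(NC2CC2)nc(Nc2ccc(C#N)cc2)n1`, 3000 nM
- compound 3 `COCCNc1cc(Oc2c(C)cc(/C=C/C#N)cc2C)cc(Nc2ccc(C#N)cc2)n1`, 58200 nM

Compound 2 gives the lowest number of the three, so it is the most toxic in this assay; compound 1 is nearest and compound 3 furthest from it, both beyond the scatter. Compound 4 `Cc1cc(/C=C/C#N)cc(C)c1Oc1cc(Cl)nc(Nc2ccc(C#N)cc2)n1` differs from compound 2 in one place: chloro in place of cyclopropylamino on an aromatic carbon. Within the data shown here, the only measured step, a 7.3-fold higher number from compound 1 to compound 3 (0.86 log units; beyond the scatter), concerns a different place and a different kind of group, so it does not bear directly on this change. Among the measured compounds shown here, no step on the shared core is known. The size and direction of the expected step are therefore uncertain, and compound 4 is expected to stay close to compound 2, with the estimated step of a 1.3-fold higher number from compound 2 to compound 4 (0.12 log units; within the scatter). The estimate for compound 4 is 4000 nM, within 1000 nM to 20000 nM.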

Compound 4, half-maximal cytotoxic concentration: 4310 nM
Compound 4: middle estimate off by 1.1-fold (0.03 log units), on the low side; measured number inside the range.
By their numbers in this assay, from the lowest: compounds 2, 4 and 1 (each within the scatter of the next, the first and the last beyond it); then compound 3.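

In this assay, chloro in place of cyclopropylamino on this aromatic carbon gives a 1.4-fold higher number from compound 2 to compound 4 (0.16 log units; within the scatter), so a single chlorine atom and a group with a three-membered ring leave the number the same within the scatter. Among these compounds, this is the first step seen at this place on the shared core, since the earlier step concerned a different place and different groups. No measurement here explains this result. On these data alone, whether a morpholine ring or a longer chain carrying an amine at this place would also stay close to compound 2 remains open.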